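From 1-(trifluoromethyl)cyclopropyl to oxan-3-yl on the carbonyl

A few compounds are considered here, and "the series" means these few. Any claim that something is new, unique, unknown or untested is made for them only; others in the source may bear on it.

Within the data shown here, in a physicochemical assay for solubility, read by mass spectrometry, in phosphate buffer, with a stated time of 24 h, at pH 7.4 (on this read-out lower numbers stand for lower solubility and higher numbers for higher solubility), compound 3 `O=C(Nc1ccc(C(F)(F)F)c(F)c1)NC1CCN(C(=O)C2(C(F)(F)F)CC2)CC1` gives 0.08 ug/mL, the lowest of the three numbers so far. Compound 2 `O=C(Nc1ccc(C(F)(F)F)c(F)c1)NC1CCN(C(=O)C2CC2)CC1` gives 0.46 ug/mL, and compound 1 `O=C(Nc1ccc(C(F)(F)F)cc1)NC1CCN(C(=O)C2CCCOC2)CC1` gives 1.1 ug/mL. Compound 4 `O=C(Nc1ccc(C(F)(F)F)c(F)c1)NC1CCN(C(=O)C2CCCOC2)CC1` is still unmeasured, and the change leading to it is oxan-3-yl in place of 1-(trifluoromethyl)cyclopropyl on a carbonyl carbon. The closest measured step is a 5.8-fold lower number from compound 2 to compound 3 (0.76 log units; beyond the scatter), modest but beyond the scatter, with trifluoromethyl in place of hydrogen on a saturated ring carbon. The change to compound 4 removes that trifluoromethyl and also swaps the ring. Compound 1, which also carries oxan-3-yl on a carbonyl carbon, stands at 1.1 ug/mL, though its core is not that of compound 4. Among the measured compounds shown here, no measured step isolates oxan-3-yl. A rise in this assay beyond the scatter, somewhat larger than the measured step, is therefore expected: an 8.8-fold higher number from compound 3 to compound 4 (0.94 log units; beyond the scatter). For compound 4 the estimated value is 0.7 ug/mL, with an expected range of 0.25 ug/mL to 2 ug/mL.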

Compound 4, solubility: 11 ug/mL
Compound 4: the middle estimate sits 16-fold (1.20 log units) below what was measured; measured number outside the range, above it.
By their numbers in this assay, from the lowest: compound 3; then compound 2; then compound 1; then compound 4.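

In this assay, among these compounds, the group on this carbonyl carbon moves the number much further than the earlier compounds showed: a 140-fold higher number from compound 3 to compound 4 (2.14 log units; beyond the scatter), and a 24-fold higher number from compound 2 to compound 4 (1.38 log units; beyond the scatter), both with oxan-3-yl entering on the shared core. The rise is not confined to the loss of trifluoromethyl, as the step from cyclopropyl, which carries none, is also large. With oxan-3-yl held in place, fluoro in place of hydrogen on an aromatic carbon also goes with a higher number, a 10-fold higher number from compound 1 to compound 4 (1.00 log units; beyond the scatter), a direction that compound 1 alone could not show.

From the compounds shown here alone, whether the rise follows the ring oxygen of oxan-3-yl or the six-membered ring as such stays open, and cyclohexyl on the same carbonyl carbon would separate the two. Nothing available bears on why these steps are so large.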